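The source may report more compounds than this note shows. Statements on the series, on what has been measured and on what is new or still open speak of the compounds shown alone.

Compound 3 `CNC(=O)Nc1ccc2c(c1)nc(SCc1cc([N+](=O)[O-])ccc1OC)n2C(C)C` gives 3300 nM in an assay on isolated protein for inhibition of Gonadotropin-releasing hormone receptor (Homo sapiens) (a lower number here means a stronger inhibitor, a higher number a weaker inhibitor), the highest of the three numbers; the shared core carries a methylcarbamoyl group on the exocyclic nitrogen. Compound 1 `COc1ccc([N+](=O)[O-])cc1CSc1nc2cc(NC(=O)C(C)(C)C)ccc2n1C(C)C` gives 180 nM, and compound 2 `COc1ccc([N+](=O)[O-])cc1CSc1nc2cc(NC(=O)NC(C)(C)C)ccc2n1C(C)C` gives 62 nM. The step from compound 4 `COc1ccc([N+](=O)[O-])cc1CSc1nc2cc(NC(=O)NC3CC3)ccc2n1C(C)C` back to compound 3 is cyclopropyl in place of methyl on an amide-type nitrogen. The step that bears on it is a 53-fold higher number from compound 2 to compound 3 (1.73 log units; beyond the scatter), a large loss when the substituent on that amide-type nitrogen shrinks from tert-butyl to methyl; growing it to cyclopropyl is expected to recover part of that, so a modest-to-large fall in this assay is expected, a 5.5-fold lower number from compound 3 to compound 4 (0.74 log units; beyond the scatter). Compound 4 is estimated at 600 nM, within a range of 200 nM to 2000 nM.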

Compound 4, half-maximal inhibitory concentration: 1900 nM
Estimate against measurement, compound 4: 3.2-fold (0.50 log units) below; measured number inside the range.
By their numbers in this assay, from the lowest: compound 2; then compound 1; then compounds 4 and 3 (each within the scatter of the next).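

In this assay, cyclopropyl and methyl on the amide-type nitrogen cannot be told apart (a 1.7-fold lower number from compound 3 to compound 4 (0.24 log units; within the scatter)). The cyclopropyl compound therefore stays far from the tert-butyl compound (a 31-fold higher number from compound 2 to compound 4 (1.49 log units; beyond the scatter)), and cyclopropylamino on the carbonyl carbon also falls well short of tert-butyl at that carbon (an 11-fold higher number from compound 1 to compound 4 (1.02 log units; beyond the scatter)). Ring formation alone thus recovers none of the large loss seen on shrinking tert-butyl. On these data alone, whether isopropyl or cyclobutyl on that nitrogen would close the gap remains open. Nothing available explains the gap.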